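A few compounds are considered here, and "the series" means these few. Any claim that something is new, unique, unknown or untested is made for them only; others in the source may bear on it.

Measured so far in a functional assay on A549 cells (Homo sapiens) for cytotoxicity, read by MTT assay (a higher number here means a weaker inhibitor, a lower number a stronger inhibitor), each value a limit of the assay and not a number:
- Compound 1 `N#Cc1c(F)c(F)c2nc(N)nc(N)c2c1F` gives > 1000 ug/mL
- Compound 2 `N#Cc1c(Nc2ccccc2)c(F)c2nc(N)nc(N)c2c1F` gives > 1000 ug/mL
- Compound 3 `CC(C)(C)Nc1c(C#N)c(F)c2c(N)nc(N)nc2c1F` gives > 1000 ug/mL

Compound 3 has no exact number, only a limit: the limit of > 1000 ug/mL in this assay, at which 3 of the 3 values shown sit. Compound 4 `CCN(CC)c1c(C#N)c(F)c2c(N)nc(N)nc2c1F` has the same atoms joined differently, with diethylamino in place of (tert-butyl)amino on an aromatic carbon.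

For the measured compounds named here, the steps that bear on this change are a step that the two limits leave unreadable from compound 1 to compound 3 and a step that the two limits leave unreadable from compound 2 to compound 3 and also a step that the two limits leave unreadable from compound 1 to compound 2. None has a readable size, so none points in either direction. The expected step is a number no higher from compound 3 to compound 4 (the limit leaves the size open), with nothing expected beyond the usual scatter. For compound 4 the estimate is 1000 ug/mL, with an expected range from 500 ug/mL to 2000 ug/mL, and another limit is the likeliest report.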

Compound 4, half-maximal inhibitory concentration: 26.5 ug/mL
Estimate against measurement, compound 4: 38-fold (1.58 log units) above, and the stated range ends above it.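

In this assay, the group on this aromatic carbon makes a large difference: diethylamino gives an at least 37-fold lower number from compound 3 to compound 4 (1.57 log units; beyond the scatter), and likewise an at least 37-fold lower number from compound 2 to compound 4 (1.57 log units; beyond the scatter) and an at least 37-fold lower number from compound 1 to compound 4 (1.57 log units; beyond the scatter). Diethylamino and (tert-butyl)amino have the same heavy atoms, joined differently, but diethylamino has 0 hydrogen-bond donors where (tert-butyl)amino has 1. For the compounds shown here, each of these steps starts from a limit and not a number, and the steps among the earlier compounds cannot be read: the limit of > 1000 ug/mL in this assay, at which 3 of the 4 values shown sit.

From the compounds shown here alone, whether the missing amine hydrogen or the two ethyl chains matter more stays open. A dimethylamino group or a piperidine ring on this carbon would help separate the two.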